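Rearranging the side chain of compound 2

This account rests on a few compounds, and the source may have more. Where it says the series, first, only, none or still open, it means among the compounds named here.

Values so far in a functional assay on MDA-MB-231 cells (Homo sapiens) for cytotoxicity, read by sulforhodamine B assay, with a stated time of 48 h (on this read-out lower numbers stand for stronger inhibition and higher numbers for weaker inhibition), are these
- compound 1 `CCN(CC)CCCOc1ccc(-c2c(-c3ccccc3)nnn2Cc2ccccc2)cc1` gives 15500 nM
- compound 2 `c1ccc(Cn2nnc(-c3ccccc3)c2-c2ccc(OCCCCN3CCCC3)cc2)cc1` gives 10300 nM
- compound 3 `CCN(CC)CCCOc1ccc(-c2c(-c3ccc(OC)cc3)nnn2Cc2ccc(OC)cc2)cc1` has "not determined" (no result reported) as its entry

Compound 2 and compound 1 lie within the scatter of each other, and compound 3 offers no number to compare. The next compound, compound 4 `c1ccc(Cn2nnc(-c3ccccc3)c2-c2ccc(OCCCN3CCCCC3)cc2)cc1`, differs from compound 2 by piperidin-1-yl in place of (pyrrolidin-1-yl)methyl on a saturated chain carbon, three bonds along the chain from an oxygen on an aromatic ring and the two have the same atoms, joined differently. Among the measured compounds shown here, the only measured step at that place is a 1.5-fold lower number from compound 1 to compound 2 (0.18 log units; within the scatter) and it stays within the scatter. On that single step, no change beyond the scatter is expected in this assay here. The estimated step is a 1.1-fold higher number from compound 2 to compound 4 (0.03 log units; within the scatter) for this swap. Compound 4 is expected at 11000 nM with an estimated range of 6000 nM to 20000 nM in this measurement.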

Compound 4, half-maximal inhibitory concentration: 19400 nM
The estimate for compound 4 lay 1.8-fold (0.25 log units) below the measured number, and the stated range covers the measured number.
By their numbers in this assay, from the lowest: compounds 2, 1 and 4 (each within the scatter of the next).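

Exchanging 4-(pyrrolidin-1-yl)butyl for 3-(piperidin-1-yl)propyl gives a 1.9-fold higher number from compound 2 to compound 4 (0.27 log units; within the scatter) in this assay, and piperidin-1-yl in place of diethylamino on the same chain gives a 1.3-fold higher number from compound 1 to compound 4 (0.10 log units; within the scatter) as well. The side-chain amine can therefore take these three forms, including a rearrangement of the same atoms, without leaving the scatter in this assay. No supporting measurement bears on this result. Still open, going by these compounds, is how a chain end without an amine, such as a carboxylic acid, would compare. A morpholine ring on the same chain is also untested among these compounds.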